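The source may hold more compounds than are shown below. What is called first, only, known or untested is meant among the compounds shown, and "the series" means these compounds.

Compound 1 `Cc1cc(Cl)cc(-c2ccnc3cc(CN4C(=O)C5C(C4=O)C5(C)C)sc23)c1C[C@@H]1CNCCO1` and compound 2 `Cc1cc(Cl)cc(-c2ccnc3cc(CN4C(=O)C5CC5C4=O)sc23)c1C[C@@H]1CNCCO1` were both tested in an assay on isolated protein for inhibition of ubiquitin carboxyl-terminal hydrolase 7 (Homo sapiens), read by fluorescence, with stated times of 30 min and 1 h; a higher number here means a weaker inhibitor, a lower number a stronger inhibitor. In this assay compound 1 gives 0.44 nM, the higher of the two numbers, while compound 2 gives 0.16 nM. Going by the values given here, the only measured step, a 2.8-fold lower number from compound 1 to compound 2 (0.44 log units; beyond the scatter), changes a group on a saturated chain carbon bound to an aromatic carbon. Compound 3 `Cc1cc(Cl)cc(-c2ccnc3cc(CN4C(=O)C5C(C4=O)C5(C)C)sc23)c1O[C@@H]1CCNC[C@@H]1C` differs from compound 1 at a different place: (3-methylpiperidin-4-yl)oxy in place of (morpholin-2-yl)methyl on an aromatic carbon. Among the compounds with values here, no measured step touches that position, so the expectation rests on compound 1 alone, and the step of a 1.1-fold higher number from compound 1 to compound 3 (0.06 log units; within the scatter) is expected to stay within the scatter. Compound 3 is therefore estimated at 0.5 nM, within a range from 0.15 nM to 1.6 nM.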

Compound 3, half-maximal inhibitory concentration: 0.18 nM
The estimate for compound 3 lay 2.8-fold (0.44 log units) above the measured number; measured number inside the range.
By their numbers in this assay, from the lowest: compounds 2 and 3 (each within the scatter of the next); then compound 1.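

In this assay, this position on the aromatic carbon accepts a substantial swap: (3-methylpiperidin-4-yl)oxy in place of (morpholin-2-yl)methyl gives a 2.4-fold lower number from compound 1 to compound 3 (0.39 log units; beyond the scatter). Going by these compounds alone, the earlier compounds left this position untouched, so this is the first sign that changing it can lower the number. No measurement shown explains the drop.

On these data alone, the new group differs in its ring, its link and its methyl all at once, so the contribution of each remains unknown. A plain (piperidin-4-yl)oxy group, without the methyl, would help separate them.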